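Cytotoxicity in the biphenylmethyl-imidazole aniline series: compound 4

This account rests on a few compounds, and the source may have more. Where it says the series, first, only, none or still open, it means among the compounds named here.

Measured so far:
- compound 1, `c1ccc(-c2ccc(Cn3cncc3CNc3cccc(-c4ccccc4)c3)cc2)cc1`: in a toxicity assay on NIH3T3 cells (Mus musculus) for cytotoxicity, read by resazurin assay (on this read-out higher numbers stand for an effect only at larger amounts of compound and lower numbers for an effect already at smaller amounts), compound 1 gives 10000 nM.
- compound 2, `c1ccc(-c2ccc(Cn3cncc3CNc3ccc(N4CCCCC4)c(-c4ccccc4)c3)cc2)cc1`: in this assay compound 2 gives > 1000 nM, which is a limit of the assay and not a number.
- compound 3, `CNC(=O)c1ccc(NCc2cncn2Cc2ccc(-c3ccccc3)cc2)cc1-c1ccccc1`: in this assay compound 3 gives > 1000 nM, again a limit of the assay and not a number.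

Compound 3 therefore stands only at a limit in this assay; one of the two other values shown is a limit as well, so its position relative to compound 2 cannot be read. The steps that touch compound 3, a step that the limit leaves unreadable from compound 1 to compound 3 and a step that the two limits leave unreadable from compound 2 to compound 3, are both left unreadable by the limits, as is a step that the limit leaves unreadable from compound 1 to compound 2; the common cause is the limit of > 1000 nM in this assay, at which 2 of the 3 values shown sit.

Compound 4, `c1ccc(-c2ccc(Cn3cncc3CNc3ccc(N4CCCC4)c(-c4ccccc4)c3)cc2)cc1`, differs from compound 3 as follows: pyrrolidin-1-yl in place of methylcarbamoyl on an aromatic carbon. Among the compounds with values here, no measured step shows a readable size for a change of this kind, and the only compound that carries a comparable cyclic amine on that carbon, compound 2, sits at the limit itself. Compound 4 is therefore expected to fall near the same limit in this assay, with no direction beyond the scatter assignable; the step from compound 3 is estimated as a step that the limit leaves unreadable from compound 3 to compound 4. For compound 4 the estimate in this assay is 3000 nM, within 1000 nM to 10000 nM.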

Compound 4, half-maximal effective concentration: > 1000 nM
Compound 4: a limit, no number (the forecaster's own chance of this, stated with the estimate: 60%); the middle value is on the limit's open side.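

No step from compound 1, compound 2 or compound 3 to compound 4 can be read in this assay, because each involves a limit: the limit of > 1000 nM in this assay, at which 3 of the 4 values shown sit.

The compounds shown leave open whether pyrrolidin-1-yl, piperidin-1-yl or methylcarbamoyl on this aromatic carbon gives a different value from the others, or from the hydrogen of compound 1.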